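Urea series: carbamoyl in place of fluoro on compound 2

The source may hold more compounds than are shown below. What is called first, only, known or untested is meant among the compounds shown, and "the series" means these compounds.

Working notes on three ureas sharing one core. Compound 1 `Cc1cc(NC(=O)Nc2ncccc2C)c2ccccc2n1` gives in an ADME assay on HepG2 cells (Homo sapiens) for cytotoxicity, with a stated time of 72 h (on this read-out lower numbers stand for an effect already at smaller amounts and higher numbers for an effect only at larger amounts of compound), only a limit, > 25000 nM. Compound 2 `Cc1cc(NC(=O)Nc2ccccc2F)c2ccccc2n1` likewise gives only a limit in this assay, > 25000 nM. Compound 3 `Cc1cc(NC(=O)Nc2ccc(F)cc2)c2ccccc2n1` also returns only a limit, > 25000 nM. Compound 2 thus stands at the limit, as do the two other values shown; see (the limit of > 25000 nM in this assay, at which 3 of the 3 values shown sit). The steps a step that the two limits leave unreadable from compound 1 to compound 2, a step that the two limits leave unreadable from compound 1 to compound 3 and a step that the two limits leave unreadable from compound 2 to compound 3 are all unreadable between limits. Compound 4 `Cc1cc(NC(=O)Nc2ccccc2C(N)=O)c2ccccc2n1` differs from compound 2 by carbamoyl in place of fluoro on an aromatic carbon. Going by the values given here, no measured step bears readably on this change. The expected step that the limit leaves unreadable from compound 2 to compound 4 is none beyond the scatter, with this assay likely again reporting only a limit. Compound 4 is therefore estimated at 35000 nM, within 12000 nM to 100000 nM.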

Compound 4, half-maximal effective concentration: > 25000 nM
Compound 4 was reported as a limit; the forecaster's own chance of this, stated with the estimate: 80%; the middle value is on the limit's open side.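

Compound 2 and compound 4 both sit at a limit, so no new step can be read between them: the limit of > 25000 nM in this assay, at which 4 of the 4 values shown sit.

The compounds shown leave open at what concentration any of these ureas would reach its half-maximal effect in this assay.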